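Removing a ring methyl from compound 1

The source may hold more compounds than are shown below. What is called first, only, known or untested is meant among the compounds shown, and "the series" means these compounds.

Measured so far:
Compound 1 `CCCNc1nc(NCc2ccc(C(=O)Nc3ccc(F)cc3)cc2)c2cc(C)ccc2n1`: 1200 nM
Compound 2 `C=CCNc1nc(NCc2ccc(C(=O)Nc3ccc(F)cc3)cc2)c2cc(C)ccc2n1`: 13000 nM

In a functional assay on HCT-116 cells (Homo sapiens) for inhibition, read by luminescence and resazurin assay, with a stated time of 3 days (on this read-out higher numbers stand for weaker inhibition and lower numbers for stronger inhibition), compound 1 gives the lowest of the two numbers; the only other result is an 11-fold higher number from compound 1 to compound 2 (1.03 log units; beyond the scatter). Compound 3 `CCCNc1nc(NCc2ccc(C(=O)Nc3ccc(F)cc3)cc2)c2ccccc2n1` differs from compound 1 by hydrogen in place of methyl on an aromatic carbon. Among the measured compounds shown here, the single measured step concerns the saturated chain on the ring nitrogen, not the aromatic ring, so no measured step bears on this change, and the data give no ground for a step beyond the scatter. Compound 3 is therefore expected to give 1600 nM, within a range from 600 nM to 4500 nM. This amounts to an expected step of a 1.3-fold higher number from compound 1 to compound 3 (0.12 log units; within the scatter).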

Compound 3, half-maximal inhibitory concentration: 1500 nM
For compound 3 the middle estimate is 1.1-fold (0.03 log units) above the measured one; the measured number falls inside the stated range.
By their numbers in this assay, from the lowest: compounds 1 and 3 (each within the scatter of the next); then compound 2.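

In this assay, hydrogen in place of methyl on this aromatic carbon gives a 1.3-fold higher number from compound 1 to compound 3 (0.10 log units; within the scatter), so this position tolerates losing the methyl on this read-out. The earlier chain change, by contrast, gave an 11-fold higher number from compound 1 to compound 2 (1.03 log units; beyond the scatter), a shift that this ring change does not approach. No available evidence accounts for this result.

The compounds shown leave open how a larger group on this aromatic carbon, such as chlorine or methoxy, would read. They also leave open whether a vinyl-ended chain or a longer chain would behave the same on the core of compound 3.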